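A few compounds are considered here, and "the series" means these few. Any claim that something is new, unique, unknown or untested is made for them only; others in the source may bear on it.

Measured in a functional assay on MDA-MB-231 cells (Homo sapiens) for antiproliferative activity, read by MTT assay; on this read-out lower numbers stand for stronger inhibition and higher numbers for weaker inhibition:
- compound 1 `CCCC/C=C\CCCCCCCCCc1cc(=O)c2c(O)cc(OCOC)cc2o1`: > 87000 nM, a limit
- compound 2 `CCCC/C=C\CCCCCCCCCc1cc(=O)c2c(O)c(C)c(OCOC)cc2o1`: > 87000 nM, a limit
- compound 3 `CCCC/C=C/CCCCCCCCCC1(O)CC(=O)C2=C(O)C(C)C(O)C(C)=C2O1`: 6790 nM

Compound 2 has no numeric value, only the limit > 87000 nM. It stands at the limit of > 87000 nM in this assay, at which 2 of the 3 values shown sit. Compound 4 `CCCCCCCCCCCCCCCc1cc(=O)c2c(O)c(C)c(OCOC)cc2o1` differs from compound 2 as follows: hexyl in place of hex-1-en-1-yl on a saturated chain carbon, nine bonds along the chain from an aromatic carbon. For the measured compounds named here, the only measured step is a step that the two limits leave unreadable from compound 1 to compound 2. That step concerns a methyl, not the chain, and has no readable size to carry over. No step beyond the scatter is therefore expected in this assay, and no direction can be given. The expected step is a step that the limit leaves unreadable from compound 2 to compound 4. Compound 4 is estimated at 90000 nM, within a range of 30000 nM to 200000 nM, and only a limit may again be reported.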

Compound 4, half-maximal inhibitory concentration: > 87000 nM
Compound 4: no number, only a limit; the forecaster's own chance of this, stated with the estimate: 75%; the middle value is on the limit's open side.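

Compound 2 and compound 4 each give only a limit in this assay, so no step can be read between them: the limit of > 87000 nM in this assay, at which 3 of the 4 values shown sit.

The compounds shown leave open whether hexyl in place of hex-1-en-1-yl changes the activity at all.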